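Isopropyl to 4-methylphenyl on an aromatic nitrogen

The source may hold more compounds than are shown below. What is called first, only, known or untested is meant among the compounds shown, and "the series" means these compounds.

In a functional assay on HCT-15 cells (Homo sapiens) for antiproliferative activity, read by MTT assay, with a stated time of 72 h (a higher number here means a weaker inhibitor, a lower number a stronger inhibitor), compound 1 (`COc1cc(-c2nccn2C(C)C)cc(OC)c1OC`) reaches only a limit (> 100000 nM) and no number. Compound 2 (`COc1cc(-c2nccn2S(=O)(=O)c2ccccc2)cc(OC)c1OC`) also reaches only a limit (> 100000 nM) and no number. Compound 1 thus stands at the limit of > 100000 nM in this assay, at which 2 of the 3 values shown sit, and offers no firm starting value. Only compound 3 (`COc1ccc(-n2ccnc2-c2cc(OC)c(OC)c(OC)c2)cc1[N+](=O)[O-]`) gives a true number (1000 nM) here.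

Compound 4 (`COc1cc(-c2nccn2-c2ccc(C)cc2)cc(OC)c1OC`) keeps the core of compound 1 and places 4-methylphenyl in place of isopropyl on an aromatic nitrogen. Going by the values given here, no measured step covers this change. The expectation rests on compound 3, which gives 1000 nM with a six-membered aromatic ring of carbon only on that nitrogen. Compound 2 goes against any simple reading, since it also carries a ring there yet stays at its limit. A stronger inhibitor is therefore expected, and the estimated step (an at least 33-fold lower number from compound 1 to compound 4 (1.52 log units; beyond the scatter)) carries wide uncertainty. The estimate for compound 4 is 3000 nM (expected range 200 nM to 40000 nM).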

Compound 4, half-maximal inhibitory concentration: 800 nM
For compound 4 the middle estimate is 3.8-fold (0.57 log units) above the measured one; low and high end bracket the measured number.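

In this assay, going by these compounds alone, 4-methylphenyl on the aromatic nitrogen gives the only measured step at this position, an at least 120-fold lower number from compound 1 to compound 4 (2.09 log units; beyond the scatter). With the rest of compound 1 unchanged, the group on this nitrogen alone separates a limit from a true number. The size of the step remains a lower bound, as compound 1 offers only a limit: the limit of > 100000 nM in this assay, at which 2 of the 4 values shown sit.

The compounds shown leave open whether the methyl of the 4-methylphenyl group contributes to this gain, or whether the six-membered aromatic ring alone is enough. They also leave open how a phenyl ring bearing an amine or a carboxylic acid, or a longer alkyl chain on the same nitrogen, would read in this assay.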